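Swapping the pyrazole aryl group in a thiazolyl-pyrazole carboxylic acid

The source may report more compounds than this note shows. Statements on the series, on what has been measured and on what is new or still open speak of the compounds shown alone.

Going by the values given here, in a functional assay on BJAB cells (Homo sapiens) for antiproliferative activity, with a stated time of 4 days (a lower number here means that less compound is needed, a higher number that more compound is needed for the effect), compound 1 `COc1cc(-c2c(C)nn(-c3nc(-c4ccc(Cl)c(Cl)c4)c(SC(C)C)s3)c2C(=O)O)cc(C(F)(F)F)c1` gives 1380 nM and is the only member of this small set with a number: compound 2 `Cc1c(-c2cc(Cl)cc(Cl)c2)c(C(=O)O)nn1-c1nc(-c2cccnc2)c(SC(C)C)s1` is reported in this assay as "not active" (no number reported) and compound 3 `Cc1c(-c2cc(Cl)cc(Cl)c2)c(C(=O)O)nn1-c1nc(-c2cnn(C)c2)c(SC(C)C)s1` as "not active" (no number reported), both without a figure. Compound 4 `Cc1nn(-c2nc(-c3ccc(Cl)c(Cl)c3)c(SC(C)C)s2)c(C(=O)O)c1-c1cnn(C)c1` differs from compound 1 by 1-methyl-1H-pyrazol-4-yl in place of 3-methoxy-5-(trifluoromethyl)phenyl on an aromatic carbon, while the rest of the shared core is unchanged. Among the compounds with values here, no step between two measured compounds is recorded, so the estimate rests on compound 1 alone. The expectation is a loss in this assay beyond the scatter, a step of a 4.3-fold higher number from compound 1 to compound 4 (0.64 log units; beyond the scatter), with a real chance that no number is returned. Compound 4 is therefore estimated at 6000 nM, in a range from 1500 nM to 25000 nM.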

Compound 4, half-maximal effective concentration: 6800 nM
Estimate against measurement, compound 4: 1.1-fold (0.05 log units) below; the range from low to high includes it.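

At this position, on an aromatic carbon of the five-membered ring, the step from a substituted phenyl to 1-methyl-1H-pyrazol-4-yl gives in this assay a 4.9-fold higher number from compound 1 to compound 4 (0.69 log units; beyond the scatter), a modest loss. The change does not abolish the effect, as compound 4 still returns a number. Nothing measured here gives a reason for the loss.

On these data alone, it remains open whether the loss follows the change of ring or the absence of the methoxy and trifluoromethyl groups. An unsubstituted phenyl or a pyridine ring here could separate the two.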